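The source may report more compounds than this note shows. Statements on the series, on what has been measured and on what is new or still open speak of the compounds shown alone.

In a functional assay (trachea) with Cavia porcellus as the target (a higher number here means that more compound is needed for the effect, a lower number that less compound is needed), compound 1 `C=CCCn1c(=O)c2[nH]cnc2n(CCC)c1=O` gives 200 nM. Compound 2 `CCCn1c(=O)n(CCC(=O)O)c(=O)c2[nH]cnc21` carries carboxy in place of vinyl on a saturated chain carbon, two bonds along the chain from an aromatic nitrogen and in this assay compound 2 gives 21200 nM, so that a 110-fold higher number from compound 1 to compound 2 (2.03 log units; beyond the scatter). Compound 3 `C=CCCn1cnc2c1c(=O)n(C)c(=O)n2CCC` rests on a core whose difference from the core of compound 1 is not broken down here; in this assay compound 3 gives 16800 nM, close to compound 2. Going by the values given here, compound 4 `CCCn1c(=O)n(C)c(=O)c2c1ncn2CCC(=O)O` is not yet measured and differs from compound 3 by carboxy in place of vinyl on a saturated chain carbon, two bonds along the chain from an aromatic nitrogen, the same change as the one from compound 1 to compound 2. Because a 110-fold higher number from compound 1 to compound 2 (2.03 log units; beyond the scatter), the number for compound 4 is expected to rise as well. For compound 4 the expected step is an 18-fold higher number from compound 3 to compound 4 (1.25 log units; beyond the scatter), kept smaller than the earlier one since compound 3 already gives 16800 nM. In this assay compound 4 is estimated at 300000 nM, between 60000 nM and 1500000 nM.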

Compound 4, half-maximal effective concentration: > 100000 nM
Compound 4 gave a limit, no number; the forecaster's own chance of this, stated with the estimate: 45%; the middle value does not contradict the limit.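

In this assay the change from vinyl to carboxy raises the number on the second core as well, giving an at least 5.9-fold higher number from compound 3 to compound 4 (0.77 log units; beyond the scatter). Compound 4 gives > 100000 nM, which is a limit of the assay and not a number. The direction of the change therefore carries over between these two cores, but its size cannot be compared: the same change on two cores in this assay, a 110-fold higher number (2.03 log units; beyond the scatter) from compound 1 to compound 2 and an at least 5.9-fold higher number (0.77 log units; beyond the scatter) from compound 3 to compound 4; the limit leaves it open whether they differ

The compounds shown leave open how a methyl ester, a primary amide or a longer chain ending in carboxy would read in this assay at the same place. They also leave open whether the change would go the same way on any core other than these two.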